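The source may hold more compounds than are shown below. What is called first, only, known or untested is meant among the compounds shown, and "the series" means these compounds.

Series notes on solubility. Compound 1 `Cc1nc(C(=O)OC2CC2)c(N)c2c1C(=O)N(Cc1ccccc1)C2=O` and compound 2 `Cc1noc(-c2nc(C)c3c(c2N)C(=O)N(Cc2ccc(F)cc2)C3=O)n1` share a core; compound 3 `Cc1noc(-c2nc(C)c3c(c2N)C(=O)N(Cc2ccc(-n4cccn4)cc2)C3=O)n1` is the member not yet measured. In a physicochemical assay for solubility, using the shake flask method, in simulated intestinal fluid, measured as kinetic solubility, with a stated time of 2 h, at 25 degrees C, at pH 6.5 (a lower number here means a less soluble compound, a higher number a more soluble compound), compound 1 gives 202000 nM. In this assay compound 2 gives only a limit of the assay, < 5000 nM, and no number. Compound 2 therefore sits at the limit of < 5000 nM in this assay, at which 1 of the 2 values shown sits, the lower of the two values shown, well apart from compound 1. The structural change from compound 2 to compound 3 is 1H-pyrazol-1-yl in place of fluoro on an aromatic carbon. For the measured compounds named here, no measured pair in the set differs in one place, so no step size for such a change can be read from the data. The step from compound 2 to compound 3 in this assay is expected to be small, a step that the limit leaves unreadable from compound 2 to compound 3, with no direction beyond the usual scatter. Compound 3 is expected to give about 3000 nM in this assay, within 500 nM to 15000 nM, with a fair chance that only a limit is reported again.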

Compound 3, solubility: < 5000 nM
Compound 3: no number, only a limit (the forecaster's own chance of this, stated with the estimate: 65%); the middle value lies beyond the limit too.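

In this assay no step from compound 2 to compound 3 can be read, as both give only a limit of the assay: the limit of < 5000 nM in this assay, at which 2 of the 3 values shown sit.

The compounds shown leave open whether 1H-pyrazol-1-yl in place of fluoro on an aromatic carbon changes the solubility read-out at all, and in which direction.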